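The source may report more compounds than this note shows. Statements on the series, on what has been measured and on what is new or still open speak of the compounds shown alone.

Measured so far:
Compound 1 `CCCCCCc1ccc(NC(=O)N[C@H](C)c2ccccc2)cc1` — in an ADME assay on the whole organism with Oryza sativa as the target, tested at 10 uM (on this read-out higher numbers stand for a weaker effect at the one concentration tested and lower numbers for a stronger effect), compound 1 gives 101%.
Compound 2 `CCCCCCCc1ccc(NC(=O)N[C@H](C)c2ccccc2)cc1` — in this assay compound 2 gives 100%.

Compound 2 holds the lower of the two numbers recorded, but its nearest neighbour is compound 1, and the step of a number 1 percentage points lower from compound 1 to compound 2 (within the scatter) lies within the scatter, so the two compounds cannot be told apart on this read-out. Going by the values given here, the only structural step measured in this set is the one from compound 1 to compound 2, which is a lengthening of the saturated chain by one carbon; it changed nothing beyond the scatter.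

The next compound, compound 3 `CCOC(=O)c1ccc(NC(=O)N[C@H](C)c2ccccc2)cc1`, differs from compound 2 in one place: ethoxycarbonyl in place of heptyl on an aromatic carbon. Among the compounds with values here, no measured step in this set involves an ethoxycarbonyl group or the removal of the heptyl chain, so the change from compound 2 to compound 3 has no direct precedent here. Within the data shown here, the one step that is known, from compound 1 to compound 2, was flat. On that basis compound 3 is expected to move by about a number 2 percentage points lower from compound 2 to compound 3 (within the scatter) relative to compound 2, which is no step beyond the scatter. The estimate for compound 3 is 98%, with a range from 85% to 108%.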

Compound 3, a percentage reported as activity, at one concentration (the size of the read-out at that concentration, not a potency): 92%
Estimate against measurement, compound 3: 6 percentage points above, and the stated range covers the measured number.
By their numbers in this assay, from the lowest: compounds 3, 2 and 1 (each within the scatter of the next).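

Exchanging the chain for ethoxycarbonyl on this aromatic carbon, para to a large group, is a much bigger change than adding one carbon to the chain, yet this assay gives a number 8 percentage points lower from compound 2 to compound 3 (within the scatter) and a number 9 percentage points lower from compound 1 to compound 3 (within the scatter) as the matching step from the hexyl compound. Going by these compounds alone, the earlier pair showed only that the length of a saturated chain made no readable difference; these steps extend that to a replacement that brings in oxygen, a double bond outside the aromatic ring and hydrogen-bond acceptors, and the three compounds still cannot be told apart on this read-out. Nothing available explains why the read-out stays within the scatter across this change.

On these data alone, it remains open whether any group at this place can move the number beyond the scatter, for instance a carboxylic acid, an amine or a much longer chain. Also open, as far as these compounds go, is whether a change elsewhere on the shared core, rather than on this aromatic carbon, would do so.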